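Sulfanyl in Place of Ethyl: Expected Spleen Activation

The source may report more compounds than this note shows. Statements on the series, on what has been measured and on what is new or still open speak of the compounds shown alone.

Measured so far:
- compound 1 `CCCCCOc1nc(N)c2nc(O)n(Cc3ccccc3)c2n1` in a functional assay (spleen, spleen) for activation, with Mus musculus as the target; on this read-out lower numbers stand for an effect already at smaller amounts and higher numbers for an effect only at larger amounts of compound: 0.01 uM
- compound 2 `CCNc1nc(N)c2nc(O)n(Cc3ccccc3)c2n1`: 1 uM
- compound 3 `CCc1nc(N)c2nc(O)n(Cc3ccccc3)c2n1`: 1 uM

Compound 3 stands level with compound 2, and together they give the highest numbers of the three; no change at the digits printed from compound 2 to compound 3 (within the scatter), so the two cannot be ordered. Against compound 1 the gap is wide: a 100-fold higher number from compound 1 to compound 3 (2.00 log units; beyond the scatter).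

Compound 4 `Nc1nc(S)nc2c1nc(O)n2Cc1ccccc1` is not yet measured. The change from compound 3 is sulfanyl in place of ethyl on an aromatic carbon.

Going by the values given here, two measured steps bear on this position. a 100-fold higher number from compound 1 to compound 2 (2.00 log units; beyond the scatter) and a 100-fold higher number from compound 1 to compound 3 (2.00 log units; beyond the scatter), so moving away from pentyloxy to a shorter group raised the number sharply both times, while no change at the digits printed from compound 2 to compound 3 (within the scatter). Sulfanyl is another short group at the same aromatic carbon, so the expectation is a step in this assay of about a 2.0-fold higher number from compound 3 to compound 4 (0.30 log units; within the scatter), within or close to the scatter. Compound 4 is therefore estimated at 2 uM, with a range from 0.5 uM to 10 uM.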

Compound 4, minimum effective concentration: 10 uM
Beside the measured number, compound 4's estimate is 5.0-fold (0.70 log units) below it; low and high end bracket the measured number.
By their numbers in this assay, from the lowest: compound 1; then compounds 2 and 3 (each within the scatter of the next); then compound 4.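

At the aromatic carbon between two ring nitrogen atoms, the identity of a small group does matter: in this assay the ethyl-to-sulfanyl change gives a 10-fold higher number from compound 3 to compound 4 (1.00 log units; beyond the scatter) and the ethylamino-to-sulfanyl change gives a 10-fold higher number from compound 2 to compound 4 (1.00 log units; beyond the scatter), whereas ethyl and ethylamino could not be told apart. Going by these compounds alone, the position therefore spans a wider range than the earlier compounds showed, with a 1000-fold higher number from compound 1 to compound 4 (3.00 log units; beyond the scatter), and compound 4 has the highest number of the four. The data shown offer no evidence on what lies behind this difference.

On these data alone, what pentylamino, pentyl or pentylsulfanyl would give at this aromatic carbon remains open, so the length of the chain cannot yet be separated from the atom linking it to the core. Whether methylsulfanyl would stay close to sulfanyl or move toward compound 1 is equally unresolved.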